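Ring size at the chain carbon: compound 3 to compound 4

This account rests on a few compounds, and the source may have more. Where it says the series, first, only, none or still open, it means among the compounds named here.

Measured so far in a functional assay on CHO cells for antagonist activity at prostaglandin E2 receptor EP3 subtype (Homo sapiens), read by cAMP accumulation, with a stated time of 30 min; a lower number here means a stronger inhibitor, a higher number a weaker inhibitor:
compound 1 `CCC(CC)C(/C=C1\OC(=O)NC1=O)c1ccc(-c2ccc3cccc(F)c3c2)[nH]c1=O` gives 23 nM
compound 2 `O=C1NC(=O)/C(=C/C(c2ccc(-c3ccc4cccc(F)c4c3)[nH]c2=O)C2CCCCC2)O1` gives 8 nM
compound 3 `O=C1NC(=O)/C(=C/C(c2ccc(-c3ccc4cccc(F)c4c3)[nH]c2=O)C2CC2)O1` gives 33 nM

Compound 3 stands at the highest number of the three in this assay. Its nearest neighbour is compound 1, and that gap is within the scatter a 1.4-fold higher number from compound 1 to compound 3 (0.16 log units; within the scatter). Within the data shown here, the gap to compound 2 is beyond the scatter a 4.1-fold higher number from compound 2 to compound 3 (0.62 log units; beyond the scatter), so compound 2 is the only one clearly separated from compound 3.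

Compound 4 `O=C1NC(=O)/C(=C/C(c2ccc(-c3ccc4cccc(F)c4c3)[nH]c2=O)C2CCCC2)O1` is not yet measured. It differs from compound 3 in one place: cyclopentyl in place of cyclopropyl on a saturated chain carbon bound to an aromatic carbon and a double-bonded chain carbon

Among the measured compounds shown here, two measured steps bear on it. Going from compound 2 to compound 3 the ring shrank and the number rose a 4.1-fold higher number from compound 2 to compound 3 (0.62 log units; beyond the scatter); going from compound 1 to compound 2 an open chain was closed to the larger ring and the number fell a 2.9-fold lower number from compound 1 to compound 2 (0.46 log units; beyond the scatter). For the measured compounds named here, the step from compound 3 to compound 4 enlarges the ring again, though not to the full size seen in compound 2, so a lower number than compound 3 is expected in this assay, but a step smaller than the one from compound 2 to compound 3.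

For compound 4 an estimated value of 14 nM is expected, within 6 nM to 32 nM. The expected step from compound 3 is a 2.4-fold lower number from compound 3 to compound 4 (0.37 log units; beyond the scatter), a number between compound 3 and compound 2 because of a 4.1-fold higher number from compound 2 to compound 3 (0.62 log units; beyond the scatter).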

Compound 4, half-maximal inhibitory concentration: 7 nM
Estimate against measurement, compound 4: 2.0-fold (0.30 log units) above; measured number inside the range.
By their numbers in this assay, from the lowest: compounds 4 and 2 (each within the scatter of the next); then compounds 1 and 3 (each within the scatter of the next).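

In this assay, the change from cyclopropyl to cyclopentyl on the saturated chain carbon gives a 4.7-fold lower number from compound 3 to compound 4 (0.67 log units; beyond the scatter), while replacing cyclohexyl with cyclopentyl gives a 1.1-fold lower number from compound 2 to compound 4 (0.06 log units; within the scatter), so the five-membered and six-membered rings cannot be told apart here and the loss seen so far belongs to the three-membered ring alone. The open pentan-3-yl group now differs from a second ring as well, with a 3.3-fold lower number from compound 1 to compound 4 (0.52 log units; beyond the scatter), so the four compounds fall into two groups: cyclopentyl and cyclohexyl in one, pentan-3-yl and cyclopropyl in the other, and a ring at this place is not enough on its own, since compound 3 goes against any rule that rings outperform the open chain. No supporting evidence bears on why the number changes with these groups.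

Cyclobutyl at this place remains open, so the ring size at which the number shifts between the two groups is not fixed. Also open, from the compounds shown here alone, is whether cycloheptyl, or a cyclohexyl ring carrying an amine or a hydroxyl group, would stay with compound 4 and compound 2.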